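This account rests on a few compounds, and the source may have more. Where it says the series, first, only, none or still open, it means among the compounds named here.

The measured compounds:
Compound 1 `CC(C)(C)OC(=O)N1CCC[C@@H]1C(=O)N1CCC(NS(=O)(=O)c2cc(S(=O)(=O)c3ccccc3)ccc2C(F)(F)F)CC1`: in a physicochemical assay for solubility (on this read-out higher numbers stand for higher solubility and lower numbers for lower solubility), compound 1 gives 25000 nM.
Compound 2 `CC(C)C(=O)N1CCC[C@H]1C(=O)N1CCC(NS(=O)(=O)c2cc(S(=O)(=O)c3ccccc3)ccc2C(F)(F)F)CC1`: in this assay compound 2 gives 100000 nM.
Compound 3 `CCNC(=O)N1CCC[C@H]1C(=O)N1CCC(NS(=O)(=O)c2cc(S(=O)(=O)c3ccccc3)ccc2C(F)(F)F)CC1`: in this assay compound 3 gives 100000 nM.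

Compound 1 stands lowest of the three in this assay. Its two neighbours sit at the same height, each a step beyond the scatter: a 4.0-fold higher number from compound 1 to compound 2 (0.60 log units; beyond the scatter) and a 4.0-fold higher number from compound 1 to compound 3 (0.60 log units; beyond the scatter). Between those two neighbours, which carry different groups on the carbonyl carbon, no change at the digits printed from compound 2 to compound 3 (within the scatter).

The unmeasured compound 4 `CC(C)(C)NC(=O)N1CCC[C@H]1C(=O)N1CCC(NS(=O)(=O)c2cc(S(=O)(=O)c3ccccc3)ccc2C(F)(F)F)CC1` differs from compound 1 in one place: 1-((tert-butyl)carbamoyl)pyrrolidin-2-yl in place of 1-(tert-butoxycarbonyl)pyrrolidin-2-yl on a carbonyl carbon.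

Both measured steps from compound 1 bear on this change, since each replaces the same 1-(tert-butoxycarbonyl)pyrrolidin-2-yl group on the same carbonyl carbon, and both gave the same modest rise. Compound 3 carries a carbamoyl group as compound 4 does, and the ethyl-to-isopropyl comparison between compound 2 and compound 3 moved nothing. A rise of about the same size is therefore expected for compound 4 in this assay, namely a 3.2-fold higher number from compound 1 to compound 4 (0.51 log units; beyond the scatter). Compound 4 is expected to read 80000 nM, with a likely range from 30000 nM to 150000 nM.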

Compound 4, solubility: 50000 nM
Compound 4: the middle estimate sits 1.6-fold (0.20 log units) above what was measured; the measured number falls inside the stated range.
By their numbers in this assay, from the lowest: compounds 1, 4, 2 and 3 (each within the scatter of the next, the first and the last beyond it).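

In this assay, putting 1-((tert-butyl)carbamoyl)pyrrolidin-2-yl in place of 1-(tert-butoxycarbonyl)pyrrolidin-2-yl on this carbonyl carbon leaves the heavy-atom count unchanged, exchanges an oxygen for a nitrogen and brings in a hydrogen-bond donor, and it gives a 2.0-fold higher number from compound 1 to compound 4 (0.30 log units; within the scatter), so this change, unlike the replacements that led to compound 2 and compound 3, does not separate from compound 1. The other two steps also stay inside the scatter, with a 2.0-fold lower number from compound 3 to compound 4 (0.30 log units; within the scatter) for tert-butyl in place of ethyl on the amide-type nitrogen and a 2.0-fold lower number from compound 2 to compound 4 (0.30 log units; within the scatter) for (tert-butyl)amino in place of isopropyl on the carbonyl carbon, which means compound 4 cannot be told apart from any of the other three, although compound 1 stands apart from compound 2 and compound 3. Nothing among the data shown offers an explanation for where compound 4 falls.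

The compounds shown leave open how this position would read with a group of another kind, such as a free amine on the pyrrolidine nitrogen or a carboxylic acid at the end of the carbamoyl chain. They also leave open what a longer chain on the amide-type nitrogen would give, since ethyl and tert-butyl are the only groups shown there.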